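Lengthening the Linker Chain: From Compound 3 to Compound 4

The source may report more compounds than this note shows. Statements on the series, on what has been measured and on what is new or still open speak of the compounds shown alone.

Measured compounds:
Compound 1, `C=CC(=O)NCCCCCCNC(=O)CCN1CCC(c2cc(OC(C)C)c(Nc3ncc(Cl)c(Nc4ccccc4S(=O)(=O)C(C)C)n3)cc2C)CC1`, gives 750 nM in a functional assay on NCI-H3122 cells (Homo sapiens) for antiproliferative activity, read by MTT assay, with a stated time of 72 h; a lower number here means a stronger inhibitor, a higher number a weaker inhibitor.
Compound 2, `C=CC(=O)NCCOCCNC(=O)CCN1CCC(c2cc(OC(C)C)c(Nc3ncc(Cl)c(Nc4ccccc4S(=O)(=O)C(C)C)n3)cc2C)CC1`, gives 150 nM in this assay.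
Compound 3, `C=CC(=O)NCCCNC(=O)CCN1CCC(c2cc(OC(C)C)c(Nc3ncc(Cl)c(Nc4ccccc4S(=O)(=O)C(C)C)n3)cc2C)CC1`, gives 1140 nM in this assay.

All three share the same core and differ only in the chain that joins the two amide-type nitrogens. Compound 3 is set apart beyond the scatter only from compound 2, by a 7.6-fold higher number from compound 2 to compound 3 (0.88 log units; beyond the scatter); against compound 1 the step of a 1.5-fold higher number from compound 1 to compound 3 (0.18 log units; within the scatter) is within the scatter, so compounds 1 and 3 cannot be told apart on these numbers.

Compound 4, `C=CC(=O)NCCCCCCCCNC(=O)CCN1CCC(c2cc(OC(C)C)c(Nc3ncc(Cl)c(Nc4ccccc4S(=O)(=O)C(C)C)n3)cc2C)CC1`, carries the change (5-((vinylcarbonyl)amino)pentyl in place of (vinylcarbonyl)amino on a saturated chain carbon, three bonds along the chain from an amide-type nitrogen). Among the measured compounds shown here, this is a further lengthening of the all-carbon chain, and the one measured step of that kind, a 1.5-fold higher number from compound 1 to compound 3 (0.18 log units; within the scatter), stayed within the scatter. The step of a 5.0-fold lower number from compound 1 to compound 2 (0.70 log units; beyond the scatter) swaps in an oxygen-containing chain and so does not bear directly on a pure lengthening. The expectation for compound 4 in this assay is therefore a step of about a 1.4-fold lower number from compound 3 to compound 4 (0.15 log units; within the scatter), not clearly beyond the scatter. Compound 4 is estimated at 800 nM, with a range from 300 nM to 2200 nM.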

Compound 4, half-maximal inhibitory concentration: 720 nM
Compound 4: middle estimate off by 1.1-fold (0.05 log units), on the high side, within the range that was stated.
By their numbers in this assay, from the lowest: compound 2; then compounds 4, 1 and 3 (each within the scatter of the next).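

In this assay, 5-((vinylcarbonyl)amino)pentyl in place of (vinylcarbonyl)amino gives a 1.6-fold lower number from compound 3 to compound 4 (0.20 log units; within the scatter), so even this extension of the all-carbon chain does not shift the number beyond the scatter. The step of a 1.0-fold lower number from compound 1 to compound 4 (0.02 log units; within the scatter) is also within the scatter, so the all-carbon chains shown cannot be told apart on these numbers. The 2-((vinylcarbonyl)amino)ethoxy chain goes against this flat picture, with a 4.8-fold higher number from compound 2 to compound 4 (0.68 log units; beyond the scatter), a gap that the longest all-carbon chain does not close.

Still open, as far as these compounds go, is whether a longer chain with several ether oxygens, or a chain carrying an amine, would match or pass that oxygen-containing chain. Nothing available here explains why the oxygen-containing chain stands apart.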